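A Heteroaryl Amide Swap on a Compound at the Limit

A few compounds are considered here, and "the series" means these few. Any claim that something is new, unique, unknown or untested is made for them only; others in the source may bear on it.

Compound 1 `COc1cc2nccc(Oc3ccc(NC(=O)c4ncc(-c5ccc(F)cc5)o4)cc3)c2cc1OC` stands at the edge of what the measurement can report. In a functional assay on HT-29 cells (Homo sapiens) for antiproliferative activity, read by MTT assay, with a stated time of 72 h (on this read-out lower numbers stand for stronger inhibition and higher numbers for weaker inhibition), compound 1 gives > 100000 nM, which is a limit of the assay and not a number. This is the limit of > 100000 nM in this assay, at which 1 of the 3 values shown sits. Compound 2 `COc1cc2c(Oc3ccc(NC(=O)C4(c5nnc(-c6ccc(F)cc6)o5)CC4)cc3F)ccnc2cc1OCCCN1CCN(C)CC1` gives 1050 nM in this assay, and compound 3 `COc1cc2c(Oc3ccc(NC(=O)C4(c5nnc(-c6ccc(F)cc6)o5)CC4)cc3F)ccnc2cc1OCCCN1CCC(C)CC1` gives 442 nM. Among the compounds with values here, the single measured step, a 2.4-fold lower number from compound 2 to compound 3 (0.38 log units; beyond the scatter), concerns the end of the side chain, not the ring attached to the carbonyl carbon, so it does not bear on the change considered here.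

Compound 4 `COc1cc2nccc(Oc3ccc(NC(=O)c4nc(-c5ccc(F)cc5)no4)cc3)c2cc1OC` carries 3-(4-fluorophenyl)-1,2,4-oxadiazol-5-yl in place of 5-(4-fluorophenyl)-1,3-oxazol-2-yl on a carbonyl carbon. Within the data shown here, no measured step speaks to this swap. Compound 4 is therefore expected to remain at the limit, with an estimate of 100000 nM (range 30000 nM to 300000 nM). The expected step of a number no higher from compound 1 to compound 4 (the limit leaves the size open) is none beyond the scatter.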

Compound 4, half-maximal inhibitory concentration: 39700 nM
Beside the measured number, compound 4's estimate is 2.5-fold (0.40 log units) above it; measured number inside the range.
By their numbers in this assay, from the lowest: compound 3; then compound 2; then compound 4. At a limit, above all of these: compound 1.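

With 3-(4-fluorophenyl)-1,2,4-oxadiazol-5-yl in place of 5-(4-fluorophenyl)-1,3-oxazol-2-yl on the carbonyl carbon, this assay gives a readable number, with an at least 2.5-fold lower number from compound 1 to compound 4 (0.40 log units; beyond the scatter). The group at this place therefore changes the read-out, which the side-chain step between compound 2 and compound 3 could not show. The true size of this step stays unknown because compound 1 is held at a limit: the limit of > 100000 nM in this assay, at which 1 of the 4 values shown sits.

Going by these compounds, what a thiazole on the carbonyl carbon would give stays open, as does the effect of a chlorine in place of the fluorine on the phenyl ring.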